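A few compounds are considered here, and "the series" means these few. Any claim that something is new, unique, unknown or untested is made for them only; others in the source may bear on it.

The measured compounds are compound 1 `O=c1[nH]nc2n(c1=O)CCN2c1ccccc1`, compound 2 `N=c1c(=O)[nH]nc2n1CCN2c1cccc(Cl)c1` and compound 3 `N=c1c(=O)[nH]nc2n1CCN2c1ccccc1`. In a functional assay on T47D cells (Homo sapiens) for cytotoxicity, with a stated time of 72 h, tested at 50 ug/mL (a higher number here means a stronger effect of the compound at the concentration tested, a lower number a weaker effect), compound 1 gives 0%, compound 2 gives 31% and compound 3 gives 3%.

Compound 2 differs from compound 3 by chloro in place of hydrogen on an aromatic carbon, and that change made a step of a number 28 percentage points higher from compound 3 to compound 2 (beyond the scatter). The difference between the cores of compound 1 and compound 3 is not broken down here. Compound 4 `O=c1[nH]nc2n(c1=O)CCN2c1cccc(Cl)c1` has not yet been measured; it differs from compound 1 by chloro in place of hydrogen on an aromatic carbon, the same change as that between compound 3 and compound 2. Beside that earlier step, the step expected from compound 1 to compound 4 is a number 20 percentage points higher from compound 1 to compound 4 (beyond the scatter), which rests on the single observed step of a number 28 percentage points higher from compound 3 to compound 2 (beyond the scatter) and on the shared starting point of a low value. Compound 4 is therefore expected to give about 20%, between 0% and 45%, in this assay.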

Compound 4, a percentage reported as inhibition, at one concentration (the size of the read-out at that concentration, not a potency): 0%
The estimate for compound 4 lay 20 percentage points above the measured number; the range from low to high includes it.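

In this assay, chloro in place of hydrogen on an aromatic carbon gave no change at the digits printed from compound 1 to compound 4 (within the scatter), so the change did not carry over from one core to the other: the same change on two cores in this assay, a number 28 percentage points higher (beyond the scatter) from compound 3 to compound 2 and no change at the digits printed (within the scatter) from compound 1 to compound 4, 28 percentage points apart, beyond the scatter of two such steps. The rise seen on the core of compound 3 therefore cannot be counted on for the core of compound 1, and the effect of this change in the series has to be read core by core. These two pairs do not show why the cores part ways, nor how any third core would respond.

The compounds shown leave open whether a different group at that place, such as bromo, methoxy or an amine, would raise the number on the core of compound 1. They also leave open how chloro would act at another place on the same aromatic ring.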